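This account rests on a few compounds, and the source may have more. Where it says the series, first, only, none or still open, it means among the compounds named here.

Measured compounds:
compound 1 `CN(C)c1ccc2cc(-c3cccc(Cl)c3)c(N)nc2c1`: 13000 nM
compound 2 `CN(C)c1ccc2cc(-c3cccc(Cl)c3Cl)c(N)nc2c1`: 4900 nM
compound 3 `CN(C)c1ccc2cc(-c3cc(Cl)cc(Cl)c3)c(N)nc2c1`: 3700 nM

In a toxicity assay on J774.A1 cells (Mus musculus) for cytotoxicity, read by SYBR Green assay, with a stated time of 1 h (on this read-out lower numbers stand for an effect already at smaller amounts and higher numbers for an effect only at larger amounts of compound), compound 1 stands highest of the three, at 13000 nM. Compound 4 `CN(C)c1ccc2cc(-c3ccccn3)c(N)nc2c1` keeps the core of compound 1 but carries pyridin-2-yl in place of 3-chlorophenyl on an aromatic carbon. Within the data shown here, two measured steps bear on this change, both chloro in place of hydrogen on an aromatic carbon: a 2.7-fold lower number from compound 1 to compound 2 (0.42 log units; beyond the scatter) and a 3.5-fold lower number from compound 1 to compound 3 (0.55 log units; beyond the scatter). Both are modest, and both run toward lower numbers in this assay as chloro is added. Compound 4 has no chloro at all, so a modest move the opposite way, toward a higher number, is expected. Among the measured compounds shown here, the data hold no measured compound with a ring nitrogen in this place, so that part of the change remains untested and the range is wide. The expected change is a 2.3-fold higher number from compound 1 to compound 4 (0.36 log units; beyond the scatter). For compound 4 the estimated value is 30000 nM, with an expected range from 11000 nM to 80000 nM.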

Compound 4, half-maximal effective concentration: 2200 nM
For compound 4 the middle estimate is 14-fold (1.13 log units) above the measured one; measured number outside the range, below it.
By their numbers in this assay, from the lowest: compounds 4, 3 and 2 (each within the scatter of the next, the first and the last beyond it); then compound 1.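

In this assay, the step at this place from 3-chlorophenyl to pyridin-2-yl gives a 5.9-fold lower number from compound 1 to compound 4 (0.77 log units; beyond the scatter), so a lower number here does not depend on chloro on the ring. The earlier steps had shown only chloro being added to a phenyl ring, with the number falling each time; this step changes the ring itself, removing chloro and bringing in a ring nitrogen, and the number still falls. No measurement shown here accounts for this shift.

From the compounds shown here alone, what a plain phenyl group would give at this place stays open, so the effects of the ring nitrogen and the lost chloro cannot be separated. Also open, going by these compounds, is how the number would respond to an amine or a carboxylic acid on this ring.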